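Mirror image of compound 2: working notes

The source may hold more compounds than are shown below. What is called first, only, known or untested is meant among the compounds shown, and "the series" means these compounds.

Measured in a functional assay on OVCAR-8 cells (Homo sapiens) for antiproliferative activity; on this read-out higher numbers stand for weaker inhibition and lower numbers for stronger inhibition:
Compound 1 `Cn1ncc(Cl)c1-c1cc(C(=O)N[C@@H]2CN[C@H](CCNS(C)(=O)=O)C[C@H]2c2ccc(F)c(F)c2)oc1Cl`: 1530 nM
Compound 2 `Cn1ncc(Cl)c1-c1cc(C(=O)N[C@@H]2CNCC[C@H]2c2ccc(C(F)(F)F)cc2)oc1Cl`: 120 nM
Compound 3 `Cn1ncc(Cl)c1-c1cc(C(=O)N[C@@H]2CN[C@H](CC(=O)O)C[C@H]2c2ccc(Cl)c(Cl)c2)oc1Cl`: 5120 nM

Compound 2 has the lowest number of the three at 120 nM, and so the strongest inhibition in this assay. Compound 1 and compound 3 both sit beyond the scatter from it on the weaker side. Neither of them forms a single-place step with compound 2 or with each other, so the set gives no measured size for any one structural change.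

The next compound is compound 4 `Cn1ncc(Cl)c1-c1cc(C(=O)N[C@H]2CNCC[C@@H]2c2ccc(C(F)(F)F)cc2)oc1Cl`. Its relation to compound 2 is the two compounds have the same atoms and bonds and differ only in configuration as drawn: 2 of 2 stereo elements differ (all stereocentres are inverted: mirror images); a stereocentre at a saturated ring carbon is drawn S in compound 2 and R in compound 4; a stereocentre at a saturated ring carbon is drawn S in compound 2 and R in compound 4. Going by the values given here, the two are mirror images, and no mirror-image pair has yet been measured, so any expectation here is a judgement with little support from the data.

Among the compounds with values here, with compound 2 at 120 nM as the lowest number so far, and every stereocentre inverted, the expected direction is toward weaker inhibition. The expected change is an 8.3-fold higher number from compound 2 to compound 4 (0.92 log units; beyond the scatter), which would lie beyond the scatter, though the low end of the range does not rule out a much smaller change. For compound 4 the estimated value is 1000 nM, with an expected range of 200 nM to 6000 nM.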

Compound 4, half-maximal inhibitory concentration: 900 nM
Estimate against measurement, compound 4: 1.1-fold (0.05 log units) above; low and high end bracket the measured number.
By their numbers in this assay, from the lowest: compound 2; then compounds 4 and 1 (each within the scatter of the next); then compound 3.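

In this assay the series now has its first mirror-image pair, and it gives a 7.5-fold higher number from compound 2 to compound 4 (0.88 log units; beyond the scatter), a modest step but one beyond the scatter. Going by these compounds alone, this is also the first single-place step in the set, so configuration at the two saturated ring carbons now has a measured size, with the form drawn S at both carbons carrying the lower number of this pair. The gap can be assigned to configuration alone, because no atom or bond separates the two structures: the fact that compounds 2 and 4 differ only in the configuration as drawn.

Going by these compounds, how the step divides between the two stereocentres stays open, and a diastereomer with only one of them inverted would be needed to apportion it. Also open, on these data alone, is whether a gap of this size holds for this mirror-image change when the trifluoromethyl group gives way to a nitrile or a methoxy group, since this pair speaks only for the trifluoromethyl compounds.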